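This account rests on a few compounds, and the source may have more. Where it says the series, first, only, none or still open, it means among the compounds named here.

Of the compounds shown here, two have been measured in an assay on isolated protein for inhibition of Leucine-rich repeat serine/threonine-protein kinase 2 (Homo sapiens), read by TR-FRET and LanthaScreen, with stated times of 50 min and 30 min, in the presence of a further agent that is not named here; on this read-out lower numbers stand for stronger inhibition and higher numbers for weaker inhibition. Compound 1, whose structure is `C[C@@H]1CCCN1c1c(C#N)c2c(N)nc(Nc3cn(C)nc3Cl)nc2n1C`, gives 34 nM in this assay. Compound 2, with the structure `Cn1c(-c2ccccc2)c(C#N)c2c(N)ncnc21`, gives 1260 nM in this assay. Compound 1 thus has the lower of the two numbers, and the gap to compound 2 lies beyond the usual scatter of repeated measurements; since the two structures differ in several places at once, that gap cannot be tied to any single change.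

Compound 3, with the structure `C[C@@H]1CCCN1c1c(C#N)c2c(N)nc(Nc3cn(C)nc3C(F)(F)F)nc2n1C`, has not yet been measured in this assay. It differs from compound 1 in one place: trifluoromethyl in place of chloro on an aromatic carbon. Within the data shown here, no measured pair in this set shows the same exchange, so there is nothing to read a direction from. Both groups carry no donors and no acceptors, and the rest of the molecule is unchanged, so a step of at most the usual scatter, in either direction, is expected from compound 1 to compound 3, written as a 1.3-fold higher number from compound 1 to compound 3 (0.12 log units; within the scatter). For compound 3 the value in this assay is accordingly estimated at 45 nM, with a range from 15 nM to 140 nM.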

Compound 3, half-maximal inhibitory concentration: 508 nM
The estimate for compound 3 lay 11-fold (1.05 log units) below the measured number; measured number outside the range, above it.
By their numbers in this assay, from the lowest: compound 1; then compound 3; then compound 2.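

In this assay, the exchange of 3-chloro-1-methyl-1H-pyrazol-4-yl for 1-methyl-3-(trifluoromethyl)-1H-pyrazol-4-yl gives a 15-fold higher number from compound 1 to compound 3 (1.17 log units; beyond the scatter), a large step well beyond the scatter. Among these compounds, this shows that the position, on an aromatic carbon of the five-membered ring, is not indifferent to the group it carries, even though neither group has hydrogen-bond donors or acceptors and the rest of the molecule is unchanged; the earlier compounds could not show this, as they differed in several places at once. The two groups differ in heavy atoms, chlorine alone against a carbon with three fluorines, but nothing available here ties the step to that difference or to any other feature of the exchange.

The compounds shown leave open how a methyl group, a single fluorine, a methoxy group or plain hydrogen at this position would compare with chloro and trifluoromethyl. They also leave open whether the same exchange would give a step of similar size and direction with a different group in place of the methyl on the ring nitrogen.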